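Moving the Chlorine Around the Phenyl Ring

The source may hold more compounds than are shown below. What is called first, only, known or untested is meant among the compounds shown, and "the series" means these compounds.

Compound 1 `Cc1ccc(-c2cc(-c3ccoc3)cc(-c3ccc(Cl)s3)n2)o1`, compound 2 `Clc1ccc(-c2cc(-c3ccoc3)cc(-c3ccccc3Cl)n2)s1` and compound 3 `Clc1cccc(-c2cc(-c3ccoc3)cc(-c3ccc(Cl)s3)n2)c1` share one core and differ only in the group on one aromatic carbon. In an assay on isolated protein for inhibition of DNA topoisomerase 1 (Homo sapiens), with a stated time of 30 min, tested at 100 uM (on this read-out higher numbers stand for more inhibition at the one concentration tested (going by the name of the read-out) and lower numbers for less inhibition), compound 1 gives 13.2%, compound 2 gives 0% and compound 3 gives 2.1%. Compound 3 thus sits well under compound 1, with a number 11.1 percentage points lower from compound 1 to compound 3 (beyond the scatter), and in the same range as compound 2, with a number 2.1 percentage points higher from compound 2 to compound 3 (within the scatter). Compound 4 `Clc1ccc(-c2cc(-c3ccoc3)cc(-c3ccc(Cl)s3)n2)cc1` carries the change (4-chlorophenyl in place of 3-chlorophenyl on an aromatic carbon). The step that bears on it most is the earlier exchange of 3-chlorophenyl in place of 2-chlorophenyl, which stayed within the scatter; the two chlorophenyl analogues also showed a number 13.2 percentage points lower from compound 1 to compound 2 (beyond the scatter) and a number 11.1 percentage points lower from compound 1 to compound 3 (beyond the scatter). A change beyond the scatter is therefore not expected. Compound 4 is estimated at 3%, between 0% and 12%. The expected step is a number 0.9 percentage points higher from compound 3 to compound 4 (within the scatter).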

Compound 4, a percentage reported as inhibition, at one concentration (the size of the read-out at that concentration, not a potency): 2.3%
Beside the measured number, compound 4's estimate is 0.7 percentage points above it, and the stated range covers the measured number.
By their numbers in this assay, from the lowest: compounds 2, 3 and 4 (each within the scatter of the next); then compound 1.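

Among 2-chlorophenyl, 3-chlorophenyl and 4-chlorophenyl, the numbers in this assay cannot be told apart, with a number 0.2 percentage points higher from compound 3 to compound 4 (within the scatter) and a number 2.3 percentage points higher from compound 2 to compound 4 (within the scatter) in this set. With a number 10.9 percentage points lower from compound 1 to compound 4 (beyond the scatter) as well, the 5-methylfuran-2-yl group of compound 1 stands apart from all three chlorophenyl groups. No measurement at hand explains why the place of the chlorine makes no readable difference.

Still open, as far as these compounds go, is whether a different group on the phenyl ring, such as an amine or a carboxylic acid, would give a higher number. Also open, from the compounds shown here alone, is whether a plain furan-2-yl group, lacking the methyl, would stay level with compound 1.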